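Working notes: loss of one aryl methyl group

A few compounds are considered here, and "the series" means these few. Any claim that something is new, unique, unknown or untested is made for them only; others in the source may bear on it.

Measured so far in an assay on isolated protein for agonist activity at Free fatty acid receptor 1 (Homo sapiens); a lower number here means that less compound is needed, a higher number that more compound is needed for the effect:
compound 1 `CC#CC(CC(=O)O)c1ccc(OCc2ccc3nc(-c4ccc(C5CCCCC5)cc4)cn3c2)cc1` gives 417 nM
compound 2 `CC#CC(CC(=O)O)c1ccc(OCc2ccc3nc(-c4ccc(C)cc4C)cn3c2)cc1` gives 316 nM
compound 3 `CC#CC(CC(=O)O)c1ccc(OCc2ccn3cc(-c4ccc(C)cc4C)nc3c2)cc1` gives 503 nM

Compound 3 has the highest of the three numbers, but its nearest neighbour compound 1 and its furthest neighbour compound 2 both lie within the scatter of it, so the three compounds cannot be told apart on this assay.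

Compound 4 `CC#CC(CC(=O)O)c1ccc(OCc2ccn3cc(-c4ccc(C)cc4)nc3c2)cc1` is compound 3 with hydrogen in place of methyl on an aromatic carbon.

Going by the values given here, only one measured step changes the aryl group: a 1.3-fold lower number from compound 1 to compound 2 (0.12 log units; within the scatter), a change far larger in size than the one now in question, yet without effect beyond the scatter. Compounds 2 and 3, which share the same aryl group and differ in the shared core, also show values within the scatter of each other. Among the compounds with values here, nothing measured bears directly on removing a single methyl from this aryl group, and the one related step argues for tolerance of changes there.

Compound 4 is therefore expected to remain close to compound 3, with a 1.0-fold lower number from compound 3 to compound 4 (0.00 log units; within the scatter) estimated as no step beyond the scatter, and an estimated value of 500 nM (range 200 nM to 1300 nM).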

Compound 4, half-maximal effective concentration: 618 nM
The estimate for compound 4 lay 1.2-fold (0.09 log units) below the measured number, and the stated range covers the measured number.
By their numbers in this assay, from the lowest: compounds 2, 1, 3 and 4 (each within the scatter of the next).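

In this assay, going by these compounds alone, the change from 2,4-dimethylphenyl to 4-methylphenyl, which replaces the methyl group ortho to a large group with hydrogen, gives a 1.2-fold higher number from compound 3 to compound 4 (0.09 log units; within the scatter) and is the first step that isolates this single position. On the core shared by compound 3 and compound 4, the methyl group at this place is therefore not needed to keep the number within the scatter, although one step on one core cannot establish a general rule for this aryl group. No measured property of these compounds accounts for this tolerance, and the observation remains purely a comparison of the two read-outs.

Going by these compounds, it remains open whether other groups at the same place, such as a methoxy group, a chlorine atom or an amine, would also leave the number within the scatter, and whether the remaining methyl group of the 4-methylphenyl ring can be replaced in the same way. Also open, on these data alone, is how the same exchange of methyl for hydrogen reads on the core of compound 2, which carries the same 2,4-dimethylphenyl group on a different core.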